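Adding a hydroxy group to the core of compound 2

The source may report more compounds than this note shows. Statements on the series, on what has been measured and on what is new or still open speak of the compounds shown alone.

Going by the values given here, compound 2 `O=c1c(Cc2coc3ccccc3c2=O)coc2ccccc12` is the only compound here with a number in a functional assay on NCI-H23 cells (Homo sapiens) for antiproliferative activity, read by XTT assay; on this read-out higher numbers stand for weaker inhibition and lower numbers for stronger inhibition: in that assay compound 2 gives 1400 nM. Compound 1 `CC(C)COc1cccc2occ(Cc3coc4ccccc4c3=O)c(=O)c12` reaches only a limit of the assay in this assay, where compound 1 gives > 10000 nM. Removing the isobutoxy group from an aromatic carbon gave an at least 7.1-fold lower number from compound 1 to compound 2 (0.85 log units; beyond the scatter), so the bare core sits at a clearly lower number than its isobutoxy-bearing partner, whose value is just the limit (the limit of > 10000 nM in this assay, at which 1 of the 2 values shown sits).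

Compound 3 `O=c1c(Cc2coc3cccc(O)c3c2=O)coc2ccccc12` differs from compound 2 by hydroxy in place of hydrogen on an aromatic carbon. Among the compounds with values here, the one measured step shows that a group on an aromatic carbon of this core raised the number considerably, but that group was the larger isobutoxy; the hydroxy group is a small group with one oxygen. On that basis a modest rise in this assay is expected, possibly staying within the scatter, as a 1.6-fold higher number from compound 2 to compound 3 (0.20 log units; within the scatter). Compound 3 is therefore estimated to give about 2200 nM in this assay, most likely between 800 nM and 7000 nM.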

Compound 3, half-maximal inhibitory concentration: 7550 nM
Beside the measured number, compound 3's estimate is 3.4-fold (0.54 log units) below it; measured number outside the range, above it.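

In this assay, hydroxy in place of hydrogen on this aromatic carbon gave a 5.4-fold higher number from compound 2 to compound 3 (0.73 log units; beyond the scatter), so the rise seen with isobutoxy does not need a group that long: hydroxy, with one heavy atom, is enough to move the number beyond the scatter. Compound 1 gives > 10000 nM, which is a limit of the assay. The step to the hydroxy compound reads an at least 1.3-fold lower number from compound 1 to compound 3 (0.12 log units; that floor lies within the scatter) and is only a floor, so hydroxy and isobutoxy cannot be put in order here: the limit of > 10000 nM in this assay, at which 1 of the 3 values shown sits.

Among the three groups shown on this carbon, hydrogen goes with the lowest number, but three groups are too few to say whether any group placed here raises it. A methoxy group, a fluorine atom or an amine on the same carbon would test this, and the same hydroxy group on another carbon of the ring would show whether the rise belongs to this position or to the group wherever it sits.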